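A Methyl Step Repeated on a Dihydroxyphenoxy Thiophene Series

A few compounds are considered here, and "the series" means these few. Any claim that something is new, unique, unknown or untested is made for them only; others in the source may bear on it.

Compound 1, `O=C(NCCNS(=O)(=O)c1sccc1-c1ccccc1Oc1ccc(O)c(O)c1)Nc1cc(Cl)cc(Cl)c1`, in a functional assay on HeLa cells (Homo sapiens) for inhibition, read by CCK-8 assay, with a stated time of 48 h (on this read-out lower numbers stand for stronger inhibition and higher numbers for weaker inhibition), is reported only as a limit of > 50000 nM.
Compound 2, `Cc1ccc(-c2ccsc2S(=O)(=O)NCCNC(=O)Nc2cc(Cl)cc(Cl)c2)c(Oc2ccc(O)c(O)c2)c1`, gives 6500 nM in this assay.
Compound 3, `O=S(=O)(NCCNC(=S)Nc1cc(C(F)(F)F)cc(C(F)(F)F)c1)c1sccc1-c1ccccc1Oc1ccc(O)c(O)c1`, is reported in this assay only as a limit of > 50000 nM.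

Compound 1 and compound 2 differ in one place: methyl in place of hydrogen on an aromatic carbon. That single change produced an at least 7.6-fold lower number from compound 1 to compound 2 (0.88 log units; beyond the scatter). The step can be stated only as a bound because the limit of > 50000 nM in this assay, at which 2 of the 3 values shown sit, caps the value of compound 1. Compound 3 is likewise reported only as a limit. How the core of compound 3 differs from the core of compound 1 is not broken down here.

Compound 4, `Cc1ccc(-c2ccsc2S(=O)(=O)NCCNC(=S)Nc2cc(C(F)(F)F)cc(C(F)(F)F)c2)c(Oc2ccc(O)c(O)c2)c1`, has not yet been measured in this assay. It stands to compound 3 as compound 2 stands to compound 1: methyl in place of hydrogen on an aromatic carbon. The surroundings of the place are described in the same words for both pairs, so this is the same change made a second time, now on a different core.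

Within the data shown here, the expectation for compound 4 rests on the one measured instance. If the methyl acts on the core of compound 3 as it did in the step of an at least 7.6-fold lower number from compound 1 to compound 2 (0.88 log units; beyond the scatter), compound 4 should come down into the measurable range, though the bound on compound 3 leaves the size uncertain. Compound 4 is therefore expected near 20000 nM, within a range from 5000 nM to 60000 nM. That estimate means an expected step of an at least 2.5-fold lower number from compound 3 to compound 4 (0.39 log units; beyond the scatter) in this assay, with a real chance that only a limit is returned.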

Compound 4, half-maximal inhibitory concentration: 8000 nM
Compound 4: middle estimate off by 2.5-fold (0.40 log units), on the high side; the range from low to high includes it.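

In this assay, methyl in place of hydrogen on an aromatic carbon, meta to the 3,4-dihydroxyphenoxy group, gave an at least 6.2-fold lower number from compound 3 to compound 4 (0.79 log units; beyond the scatter), so the change that lowered the number on the core of compound 1 also lowered it on the core of compound 3. Set side by side, the two steps run in the same direction and each lies beyond the usual scatter: the same change on two cores in this assay, an at least 7.6-fold lower number (0.88 log units; beyond the scatter) from compound 1 to compound 2 and an at least 6.2-fold lower number (0.79 log units; beyond the scatter) from compound 3 to compound 4; the limit leaves it open whether they differ. This does not give the true size of either step, and two pairs on two cores do not establish a rule for other cores in the series, as compound 1 and compound 3 are each reported only as a limit: the limit of > 50000 nM in this assay, at which 2 of the 4 values shown sit.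

The compounds shown leave open whether an ethyl group, a methoxy group or a chlorine atom at this place on the ring would lower the number as methyl does, and whether methyl would do so elsewhere on that ring. From the compounds shown here alone, compound 2 and compound 4 differ in more than one place, so it also remains open how the thiocarbonyl and the two trifluoromethyl groups each bear on the read-out.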